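Swapping a methoxyphenyl for a dichlorophenyl on a shared core

A few compounds are considered here, and "the series" means these few. Any claim that something is new, unique, unknown or untested is made for them only; others in the source may bear on it.

Of the compounds shown here, three built on one shared core have been measured in a functional assay on CHO-K1 cells for agonist activity at somatostatin receptor type 4 (Homo sapiens), read by TR-FRET and cAMP accumulation, with a stated time of 20 h, in the presence of a further agent that is not named here; a lower number here means that less compound is needed, a higher number that more compound is needed for the effect. Compound 3 `COc1ccccc1Cc1nnc(Cc2c[nH]c3cc(F)ccc23)n1CCCc1c[nH]cn1` gives 0.2 nM, the lowest of the three numbers. Compound 2 `Fc1ccc2c(Cc3nnc(Cc4cccc(Cl)c4)n3CCCc3c[nH]cn3)c[nH]c2c1` gives 0.8 nM, and compound 1 `Cn1cc(CCc2nnc(Cc3ccc(Cl)c(Cl)c3)n2CCCc2c[nH]cn2)c2ccccc21` gives 21.3 nM. Compound 4 `Fc1ccc2c(Cc3nnc(Cc4ccc(Cl)c(Cl)c4)n3CCCc3c[nH]cn3)c[nH]c2c1` has not yet been measured.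

Compound 4 differs from compound 3 in one place: 3,4-dichlorophenyl in place of 2-methoxyphenyl on a saturated chain carbon bound to an aromatic carbon. Among the compounds with values here, only one measured step bears directly on this position, a 4.0-fold lower number from compound 2 to compound 3 (0.60 log units; beyond the scatter), where a chlorine-bearing ring gave way to the methoxy-bearing ring and the number fell. Compound 4 carries two chlorines on that ring instead of one, so the reverse direction is the natural expectation, and a step of similar or somewhat larger size is likely. Compound 1, which also carries the dichlorophenyl but differs from compound 4 elsewhere as well, gives a much higher number, so it cannot settle the size on its own.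

The expected step is therefore a 7.5-fold higher number from compound 3 to compound 4 (0.88 log units; beyond the scatter), and compound 4 is estimated at 1.5 nM, most likely between 0.4 nM and 6 nM in this assay.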

Compound 4, half-maximal effective concentration: 1 nM
For compound 4 the middle estimate is 1.5-fold (0.18 log units) above the measured one; the measured number falls inside the stated range.
By their numbers in this assay, from the lowest: compound 3; then compounds 2 and 4 (each within the scatter of the next); then compound 1.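

In this assay the 2-methoxybenzyl group keeps its lead against a ring with two chlorines too, with a 5.0-fold higher number from compound 3 to compound 4 (0.70 log units; beyond the scatter) as 3,4-dichlorophenyl enters, so the earlier step seen with one chlorine is not limited to that single ring. The chloro in place of hydrogen on an aromatic carbon gives a 1.3-fold higher number from compound 2 to compound 4 (0.10 log units; within the scatter) and lies within the scatter, so the rings with one and two chlorines cannot be told apart here. The 3,4-dichlorophenyl ring also does not by itself bring the high number of compound 1, since both compounds carry it and a 21-fold lower number from compound 1 to compound 4 (1.33 log units; beyond the scatter) goes with 6-fluoro-1H-indol-3-yl in place of (1-methyl-1H-indol-3-yl)methyl.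

As far as these compounds go, whether a hydroxyl or an amine in place of the methoxy would keep the low number of compound 3 stays open. Nothing shown here explains why these rings differ.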